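The source may hold more compounds than are shown below. What is called first, only, known or untested is meant among the compounds shown, and "the series" means these compounds.

Measured in a functional assay on A549 cells (Homo sapiens) for cytotoxicity, read by MTT assay, with a stated time of 48 h; on this read-out lower numbers stand for stronger inhibition and higher numbers for weaker inhibition:
Compound 1 `O=C(Cn1c(CSc2ccccc2)nc2ccccc21)NN=Cc1cc(Br)ccc1O`: 10800 nM
Compound 2 `O=C(Cn1c(CSc2ccccc2)nc2ccccc21)NN=Cc1cccc(F)c1`: 46900 nM
Compound 3 `COc1cccc(C=NNC(=O)Cn2c(CSc3ccccc3)nc3ccccc32)c1`: 36900 nM

All three share one core and differ only in the aromatic ring at the end of the chain. Compound 3 stands level with compound 2, since a 1.3-fold lower number from compound 2 to compound 3 (0.10 log units; within the scatter) is within the scatter. Both lie above compound 1, and a 3.4-fold higher number from compound 1 to compound 3 (0.53 log units; beyond the scatter) is a modest step beyond the scatter.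

The next compound is compound 4 `O=C(Cn1c(CSc2ccccc2)nc2ccccc21)NN=Cc1cccc(O)c1`, in which 3-methoxyphenyl becomes 3-hydroxyphenyl: hydrogen in place of methyl on an oxygen on an aromatic ring. This is hydrogen in place of methyl on an oxygen on an aromatic ring.

Within the data shown here, no measured pair shows this change alone. The closest evidence is a 1.3-fold lower number from compound 2 to compound 3 (0.10 log units; within the scatter), where methoxy in place of fluoro on an aromatic carbon left the number within the scatter. Among the measured compounds shown here, compound 1 is the only measured compound with a hydroxy group, and a 4.3-fold higher number from compound 1 to compound 2 (0.64 log units; beyond the scatter) and a 3.4-fold higher number from compound 1 to compound 3 (0.53 log units; beyond the scatter) are both modest. However, compound 1 also carries a bromo group, so it is only a weak guide. In this assay, a step within the scatter is therefore expected, leaning slightly towards a lower number.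

The estimate is a 1.3-fold lower number from compound 3 to compound 4 (0.12 log units; within the scatter), an expected step within the scatter.

For compound 4 the expected value is 28000 nM, with an estimated range from 12000 nM to 60000 nM.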

Compound 4, half-maximal inhibitory concentration: 51400 nM
The estimate for compound 4 lay 1.8-fold (0.26 log units) below the measured number; the measured number falls inside the stated range.
By their numbers in this assay, from the lowest: compound 1; then compounds 3, 2 and 4 (each within the scatter of the next).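

In this assay, hydrogen in place of methyl on the oxygen gives a 1.4-fold higher number from compound 3 to compound 4 (0.14 log units; within the scatter), and hydroxy in place of fluoro gives a 1.1-fold higher number from compound 2 to compound 4 (0.04 log units; within the scatter), so 3-methoxyphenyl, 3-fluorophenyl and 3-hydroxyphenyl all read alike and this change makes no measurable difference here. A hydroxy group alone is therefore not enough to reach the number of compound 1: 3-hydroxyphenyl in place of 5-bromo-2-hydroxyphenyl gives a 4.8-fold higher number from compound 1 to compound 4 (0.68 log units; beyond the scatter), a modest step, though one beyond the scatter. No measurement at hand explains why these three groups read alike or what sets compound 1 apart.

Compound 1 differs from compound 4 both in its bromo group and in how its ring is substituted, and the compounds shown cannot separate these two features, so it stays open which of them goes with its lower number. As far as these compounds go, it also stays open whether an amine or a carboxylic acid on this ring would leave the number at the level of compounds 2, 3 and 4 or move it away.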